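A few compounds are considered here, and "the series" means these few. Any claim that something is new, unique, unknown or untested is made for them only; others in the source may bear on it.

In an ADME assay on L02 cells (Homo sapiens) for antiproliferative activity, read by MTT assay, with a stated time of 48 h (on this read-out lower numbers stand for stronger inhibition and higher numbers for weaker inhibition), compound 1 (`CCn1c(C(=O)NCCCN(C)C)ccc1C(CC)(CC)c1ccc(OCCC(O)(CC)CC)c(C)c1`) gives 2420 nM as its reading. Compound 2 (`C#CC(C)OC(=O)c1ccc(C(CC)(CC)c2ccc(OCCC(O)(CC)CC)c(C)c2)n1CC`) reads > 50000 nM and that is a limit of the assay, not a number. Going by the values given here, the only measured step bearing on the next change is large: an at least 20-fold higher number from compound 1 to compound 2 (1.31 log units; beyond the scatter) is what it shows. Compound 3 (`CCn1c(C(=O)Nc2ccc(OC(F)(F)F)cc2)ccc1C(CC)(CC)c1ccc(OCCC(O)(CC)CC)c(C)c1`) carries (4-(trifluoromethoxy)phenyl)amino in place of (1-methylprop-2-yn-1-yl)oxy on a carbonyl carbon. Among the compounds with values here, with an amino group back on that carbon, though not the one in compound 1, a moderate to large move to lower numbers in this assay is expected, probably only a partial return. The expected move is an at least 4.1-fold lower number from compound 2 to compound 3 (0.61 log units; beyond the scatter) in size. Compound 3 is estimated at 12000 nM (expected range 3000 nM to 50000 nM).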

Compound 3, half-maximal inhibitory concentration: > 50000 nM
Compound 3: no number, only a limit (the forecaster's own chance of this, stated with the estimate: 30%); middle value at least 4.1-fold (0.61 log units) from the limit.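

In this assay, an amino group on the carbonyl carbon does not by itself give a reading: with 4-(trifluoromethoxy)phenyl in place of 3-(dimethylamino)propyl on the amide-type nitrogen, the result is an at least 20-fold higher number from compound 1 to compound 3 (1.31 log units; beyond the scatter). Of the two amides, only compound 1 gives a reading, so the group on that nitrogen matters. The step from compound 2 to compound 3 cannot be read, because both compounds give only a limit: the limit of > 50000 nM in this assay, at which 2 of the 3 values shown sit.

Still open, as far as these compounds go, is which part of the 3-(dimethylamino)propyl group carries the reading. A plain propyl chain or a morpholine at the end of the chain would help to separate the amine from the chain.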